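A few compounds are considered here, and "the series" means these few. Any claim that something is new, unique, unknown or untested is made for them only; others in the source may bear on it.

For the measured compounds named here, compound 2 `CCc1sc(CCc2cc(OCc3ccccc3)cc(NCc3cc(Cl)cc(NC(=O)OC(C)C)c3)n2)nc1C` stands at the high end of the two numbers measured so far: in an assay on cells for binding affinity to Neuropeptide Y receptor type 1 (Homo sapiens) (a lower number here means a stronger inhibitor, a higher number a weaker inhibitor), compound 2 gives 237 nM. Its nearest neighbour, compound 1 `CCc1sc(CCc2cc(OC(CC)CC)cc(NCc3cc(Cl)cc(NC(=O)OC(C)C)c3)n2)nc1C`, gives 5.5 nM in this assay. Going by the values given here, the only measured step, a 43-fold higher number from compound 1 to compound 2 (1.63 log units; beyond the scatter), shows that exchanging the branched alkyl group on the aromatic oxygen for benzyl weakens binding by a large margin. Compound 3 `CCc1sc(CCc2cc(OCCCc3ccccc3)cc(NCc3cc(Cl)cc(NC(=O)OC(C)C)c3)n2)nc1C` differs from compound 2 by phenethyl in place of phenyl on a saturated chain carbon bound to an oxygen on an aromatic ring. Among the compounds with values here, no measured step bears directly on lengthening this chain, so the expectation rests on weak grounds. The step from compound 2 to compound 3 is therefore expected to be modest, with no confident direction, estimated as a 1.6-fold lower number from compound 2 to compound 3 (0.20 log units; within the scatter). For compound 3, the value in this assay is estimated at 150 nM, with a range from 25 nM to 900 nM.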

Compound 3, half-maximal inhibitory concentration: 20 nM
Compound 3: the middle estimate sits 7.5-fold (0.88 log units) above what was measured; measured number below the stated range.
By their numbers in this assay, from the lowest: compound 1; then compound 3; then compound 2.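

Lengthening the chain on the aromatic oxygen, from benzyl to 3-phenylpropyl, gives a 12-fold lower number from compound 2 to compound 3 (1.07 log units; beyond the scatter) in this assay and recovers much of the affinity lost with benzyl, so a phenyl ring at this position is compatible with strong binding when it sits further out on a longer chain. The branched pentan-3-yl group still keeps an edge, with a 3.6-fold higher number from compound 1 to compound 3 (0.56 log units; beyond the scatter) on replacing it by 3-phenylpropyl, though this gap is much smaller than the one seen with benzyl. No supporting measurement accounts for the gain from the longer chain.

Going by these compounds, with only these two chain lengths compared, it remains open whether the trend holds through 2-phenylethyl or continues to 4-phenylbutyl. On these data alone, the effect of replacing the terminal phenyl with a pyridine ring or an amine also remains open.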